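The source may hold more compounds than are shown below. What is called first, only, known or untested is meant among the compounds shown, and "the series" means these compounds.

Working notes on the series. In an ADME assay on Vero cells (Chlorocebus sabaeus) for cytotoxicity, read by CellTiter-Glo, with a stated time of 72 h (on this read-out higher numbers stand for lower toxicity in this test and lower numbers for higher toxicity in this test), compound 1 (`C[C@@H](Nc1n[n+]([O-])c2ccccc2[n+]1[O-])C1CCCCC1`) gives 8.9 ug/mL and compound 2 (`[O-][n+]1nc(N[C@@H]2C[C@H]3CC[C@@H]2C3)[n+]([O-])c2ccccc21`) gives 3.4 ug/mL. Compound 2 therefore holds the lower of the two numbers, and its gap to compound 1 lies beyond the usual scatter. Compound 3 (`[O-][n+]1nc(N[C@@H]2C[C@H]3CC[C@@H]2C3)[n+]([O-])c2ccc(Cl)cc21`) differs from compound 2 at a single place: chloro in place of hydrogen on an aromatic carbon. Going by the values given here, no measured pair shows the effect of such a change on this assay, so the expectation rests on little. A small move toward a lower number is expected, of about the size of the scatter. The expected step is a 1.4-fold lower number from compound 2 to compound 3 (0.13 log units; within the scatter). For compound 3 the estimated value is 2.5 ug/mL, with an expected range of 1 ug/mL to 6 ug/mL.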

Compound 3, half-maximal cytotoxic concentration: 1.1 ug/mL
The estimate for compound 3 lay 2.3-fold (0.36 log units) above the measured number, within the range that was stated.
By their numbers in this assay, from the lowest: compound 3; then compound 2; then compound 1.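

In this assay, going by these compounds alone, chloro in place of hydrogen on an aromatic carbon, meta to a fused ring and para to a fused ring, gives a 3.1-fold lower number from compound 2 to compound 3 (0.49 log units; beyond the scatter), the only measured step for this change. The position is therefore not silent in this test: one chlorine atom, with the rest of compound 2 kept, is enough to move the number toward higher toxicity. Nothing measured in the series gives a reason for this step.

A fluoro group, a methoxy group or a nitrile on the same aromatic carbon could show whether the step is particular to chloro. Also open, on these data alone, is whether chloro gives a like step on the other aromatic carbons of this ring, or on the core of compound 1 with its own side chain.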